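Sec-butyl in place of isobutyl: working notes

The source may report more compounds than this note shows. Statements on the series, on what has been measured and on what is new or still open speak of the compounds shown alone.

Measured so far:
- compound 1 `COc1cc(/C=C/C(=O)/C=C(/C=C/c2ccc(OC(C)=O)c(OC)c2)NC2CCCCC2)ccc1OC(C)=O` gives > 25000 nM (a limit)
- compound 2 `COc1cc(/C=C/C(=O)/C=C(/C=C/c2ccc(OC(C)=O)c(OC)c2)NCC(C)C)ccc1OC(C)=O` gives > 25000 nM (a limit)
- compound 3 `CCC(C)NC(=C\C(=O)/C=C/c1ccc(O)cc1)/C=C/c1ccc(O)cc1` gives 22000 nM

All values come from an ADME assay on EA.hy 926 cells (Homo sapiens) for inhibition, read by MTT assay, with a stated time of 72 h; on this read-out higher numbers stand for weaker inhibition and lower numbers for stronger inhibition. Compound 2 gives only the limit > 25000 nM, not a number. Within the data shown here, the series so far shows (the limit of > 25000 nM in this assay, at which 2 of the 3 values shown sit).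

The change to compound 4 `CCC(C)NC(=C\C(=O)/C=C/c1ccc(OC(C)=O)c(OC)c1)/C=C/c1ccc(OC(C)=O)c(OC)c1` is sec-butyl in place of isobutyl on an amine nitrogen, in words sec-butyl in place of isobutyl on an amine nitrogen. Among the measured compounds shown here, the one measured step at this nitrogen is a step that the two limits leave unreadable from compound 1 to compound 2, so it gives no size to carry over. Compound 3 also carries sec-butyl on an amine nitrogen and gives 22000 nM, but the rest of its structure differs, so it offers only a loose guide.

The data therefore give no ground for expecting a step beyond the scatter in this assay, in either direction. The expected change is a step that the limit leaves unreadable from compound 2 to compound 4. For compound 4 the estimated value is 30000 nM, with an expected range from 15000 nM to 60000 nM, and a report as a limit is the likeliest outcome.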

Compound 4, half-maximal inhibitory concentration: > 25000 nM
Compound 4: only a limit was reported; the forecaster's own chance of this, stated with the estimate: 70%; the middle value lies beyond the limit too.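

No step can be read among compound 1, compound 2 and compound 4 in this assay, since all three are reported only as a limit: the limit of > 25000 nM in this assay, at which 3 of the 4 values shown sit.

The compounds shown leave open whether cyclohexyl, isobutyl and sec-butyl on the amine nitrogen differ at all in their effect on this read-out.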